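Methyl in place of bromo on the fused ring

The source may report more compounds than this note shows. Statements on the series, on what has been measured and on what is new or still open speak of the compounds shown alone.

The series shares a core carrying a tetrazole, as seen in compound 1 `COc1ccc2c(=O)c(-c3nn[nH]n3)c[nH]c2c1`, compound 2 `O=c1c(-c2nn[nH]n2)c[nH]c2c(Br)cccc12` and compound 3 `Cc1ccc2[nH]cc(-c3nn[nH]n3)c(=O)c2c1`. In a functional assay on the whole organism (strain Sprague-Dawley) for inhibition, with Rattus norvegicus as the target (on this read-out higher numbers stand for an effect only at larger amounts of compound and lower numbers for an effect already at smaller amounts), compound 1 gives 10 mg/kg. In this assay compound 3 gives 1.25 mg/kg. For compound 2 this assay reports only a limit, > 5 mg/kg, and no number; this is the limit of > 5 mg/kg in this assay, at which 1 of the 3 values shown sits, so compound 2 stands apart from the two compounds for which a value is known, and its place among them cannot be fixed.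

Compound 4 `Cc1cccc2c(=O)c(-c3nn[nH]n3)c[nH]c12` has not yet been measured in this assay. It differs from compound 2 in one place: methyl in place of bromo on an aromatic carbon. Because compound 2 shows only a limit > 5 mg/kg, no measured step involving it exists, and the size of the change from compound 2 to compound 4 cannot be anchored on the numbers shown. A modest step is expected, a number no higher from compound 2 to compound 4 (the limit leaves the size open), its direction uncertain.

Compound 4 is estimated at 5 mg/kg in this assay, with a range from 1.25 mg/kg to 20 mg/kg.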

Compound 4, minimum effective dose: > 5 mg/kg
Compound 4: no number, only a limit (the forecaster's own chance of this, stated with the estimate: 40%); the middle value lies on the limit itself.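

In this assay compound 2 and compound 4 both stand only at a limit, so no step between them can be read: the limit of > 5 mg/kg in this assay, at which 2 of the 4 values shown sit.

The compounds shown leave open whether methyl in place of bromo on an aromatic carbon changes the minimum effective dose at all, and by how much.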